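This account rests on a few compounds, and the source may have more. Where it says the series, first, only, none or still open, it means among the compounds named here.

In an ADME assay on MT4 cells (Homo sapiens) for cytotoxicity, read by MTT assay (a higher number here means that more compound is tolerated, a lower number that less compound is tolerated), compound 1, whose structure is `O=C1c2ccccc2C(=O)N1CCOC(=S)N(C(=O)c1cccc([N+](=O)[O-])c1)c1ccc(Cl)cc1`, gives 18000 nM. That is the lowest of the two numbers available, so less of compound 1 is tolerated than of compound 2, `O=C1c2ccccc2C(=O)N1CCOC(=S)N(C(=O)c1ccc(Br)cc1)c1ccc(Br)cc1`, which in this assay gives 73000 nM. Compound 3, `O=C1c2ccccc2C(=O)N1CCOC(=S)N(C(=O)c1cccnc1Cl)c1ccc(Br)cc1`, reaches only a limit of the assay, > 100000 nM, in this assay. Within the data shown here, the one measured step, an at least 1.3-fold higher number from compound 2 to compound 3 (0.13 log units; that floor lies within the scatter), exchanges the aryl group on the carbonyl carbon and sits against (the limit of > 100000 nM in this assay, at which 1 of the 3 values shown sits), so its true size is open.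

Compound 4, `O=C1c2ccccc2C(=O)N1CCOC(=S)N(C(=O)c1ccc(Cl)c([N+](=O)[O-])c1)c1ccc(Cl)cc1`, has not yet been measured in this assay. It differs from compound 1 in one place: chloro in place of hydrogen on an aromatic carbon. Among the measured compounds shown here, none of the measured steps touches this position, and the change from compound 2 to compound 3 is of a different kind, so there is no step that bears on it directly. The two compounds with numbers show that a change of the aryl group on the carbonyl carbon can move the number, but a single chloro added to an aromatic carbon is a smaller alteration. The expectation is therefore a step of a 1.2-fold lower number from compound 1 to compound 4 (0.08 log units; within the scatter), within the scatter. Compound 4 is estimated to give 15000 nM, with a range from 6000 nM to 45000 nM.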

Compound 4, half-maximal cytotoxic concentration: 48000 nM
The estimate for compound 4 lay 3.2-fold (0.51 log units) below the measured number; the measured number lies above the stated range.
By their numbers in this assay, from the lowest: compound 1; then compounds 4 and 2 (each within the scatter of the next). At a limit, above all of these: compound 3.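

In this assay, the change from 3-nitrophenyl to 4-chloro-3-nitrophenyl on the carbonyl gives a 2.7-fold higher number from compound 1 to compound 4 (0.43 log units; beyond the scatter). Among these compounds, this is the first reading at this position, on an aromatic carbon ortho to a nitro group and para to a large group, and it shows that a single added chlorine here moves the number beyond the scatter, towards more compound being tolerated. Among the compounds shown here, the only step among the earlier compounds exchanged a whole aryl group and had a floor within the scatter, whereas this one is a small, fully readable change, though nothing given here accounts for its size or direction.

Whether the shift belongs to the chloro alone or depends on the nitro group beside which the data place it stays open, since every compound shown with a chloro at this position also carries that nitro group. How a fluoro, a methoxy or an amine at the same carbon would read is also unknown, as is whether the chloro would have a similar effect on the other aryl groups of the series.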